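The source may hold more compounds than are shown below. What is called first, only, known or untested is meant among the compounds shown, and "the series" means these compounds.

Measured so far:
compound 1 `CCOC(=O)c1csc2nc(CN3CCN(C)CC3)c(-c3ccc(C)cc3)n12` — 61000 nM
compound 2 `CCOC(=O)c1csc2nc(CN3CCN(Cc4ccccc4)CC3)c(-c3ccc(C)cc3)n12` — 47800 nM

Both measured compounds share one core and differ only at the amine nitrogen in the ring. In a functional assay on HCT-116 cells (Homo sapiens) for antiproliferative activity, read by MTT assay, with a stated time of 72 h (a higher number here means a weaker inhibitor, a lower number a stronger inhibitor), compound 1 gives 61000 nM, and compound 2 gives 47800 nM; the two values stand within the scatter of each other, the step being a 1.3-fold lower number from compound 1 to compound 2 (0.11 log units; within the scatter), so compound 1 cannot be set apart from compound 2 on these numbers.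

Compound 3 `CCOC(=O)c1csc2nc(CN3CCN(C)CC3)c(-c3ccc(OC)cc3)n12` is not yet measured. It keeps the methylated amine of compound 1 and differs from it at the aryl ring: methoxy in place of methyl on an aromatic carbon. Among the compounds with values here, no measured step touches this aryl position; the only step known, from the amine substitution, was within the scatter and does not bear on a change at the aromatic carbon. There is therefore no basis for expecting a shift in this assay beyond the scatter in either direction.

Compound 3 is accordingly expected to give about 60000 nM, with a range of 25000 nM to 150000 nM. The estimated step from compound 1 to compound 3 is a 1.0-fold lower number from compound 1 to compound 3 (0.01 log units; within the scatter), a change of no size beyond the scatter.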

Compound 3, half-maximal inhibitory concentration: 44600 nM
Compound 3: middle estimate off by 1.3-fold (0.13 log units), on the high side; measured number inside the range.
By their numbers in this assay, from the lowest: compounds 3, 2 and 1 (each within the scatter of the next).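

In this assay, the change from 4-methylphenyl to 4-methoxyphenyl, on an aromatic carbon para to a large group, amounts to a 1.4-fold lower number from compound 1 to compound 3 (0.14 log units; within the scatter). Within the data shown here, this is the first reading at this position, and it shows that methoxy in place of methyl, which adds one oxygen and one hydrogen-bond acceptor, does not set compound 3 apart from compound 1 on these numbers. Among these compounds, the aryl position now matches the amine nitrogen, since the single change at each site, taken from compound 1, stays within the scatter, and no information at hand bears on why this substitution gives such a result.

As far as these compounds go, two substituents at the aromatic carbon say little about the range open there, so it remains unknown whether a carboxylic acid, an amine or a longer alkoxy chain at that carbon would give a step beyond the scatter. Also open, from the compounds shown here alone, is whether any change at the ethyl ester of the shared core, such as a carboxylic acid or an amide in its place, would move the number in this assay further than the changes at the aryl ring and the amine nitrogen have.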